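The compounds below may be only part of what the source reports. "The series", "measured", "known", "first", "only" and "open" are said of these compounds alone.

Compound 1 `COc1cc(Cl)cc(-c2nn(-c3cccc(NC(=O)c4ccc(Cl)c(Cl)c4)c3)cc2-c2ccncc2)c1`: 79.2%; compound 2 `O=C(Nc1cccc(-n2cc(-c3ccncc3)c(-c3cc(O)cc(Cl)c3)n2)c1)Nc1ccc(Cl)c(C(F)(F)F)c1`: 59.3%.

In a functional assay on OVCAR-5 cells (Homo sapiens) for inhibition, read by sulforhodamine B assay, with a stated time of 48 h, tested at 10 uM (on this read-out lower numbers stand for a stronger effect and higher numbers for a weaker effect at the one concentration tested), compound 2 gives the lowest of the two numbers, and compound 1 stands higher by a gap beyond the usual scatter. Compound 3 `COc1cc(Cl)cc(-c2nn(-c3cccc(NC(=O)Nc4ccc(Cl)c(C(F)(F)F)c4)c3)cc2-c2ccncc2)c1` has not yet been measured. It differs from compound 2 in one place: methyl in place of hydrogen on an oxygen on an aromatic ring. Going by the values given here, no measured pair shows this change on its own, so its size is not known from the data; in this assay a small step in either direction, or none beyond the scatter, seems most likely. For compound 3 the expected value is 65%, within 45% to 85%, which means an expected step of a number 5.7 percentage points higher from compound 2 to compound 3 (within the scatter).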

Compound 3, a percentage reported as activity, at one concentration (the size of the read-out at that concentration, not a potency): 19.2%
Compound 3: middle estimate off by 45.8 percentage points, on the high side; the whole stated range lies above it.
By their numbers in this assay, from the lowest: compound 3; then compound 2; then compound 1.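

In this assay, going from hydroxy to methoxy on the aromatic ring gives a large step (a number 40.1 percentage points lower from compound 2 to compound 3 (beyond the scatter)), so this small change at the oxygen matters greatly at the one concentration tested. With methoxy in place, (4-chloro-3-(trifluoromethyl)phenyl)amino in place of 3,4-dichlorophenyl on the carbonyl carbon also gives a large step (a number 60 percentage points lower from compound 1 to compound 3 (beyond the scatter)). Nothing measured here explains either step. From the compounds shown here alone, whether an ethoxy group or an amine at this oxygen-bearing position would do better remains open. So does whether hydroxy to methoxy gives a similar step when 3,4-dichlorophenyl sits on the carbonyl carbon.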